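This account rests on a few compounds, and the source may have more. Where it says the series, first, only, none or still open, it means among the compounds named here.

Working notes on the series. The shared core, as in compound 1 `COCC/C(=C(/c1ccc(/C=C/C(=O)O)cc1)c1ccc2[nH]ncc2c1)c1ccccc1`, carries a chain on a double-bonded chain carbon bound to an aromatic carbon and a double-bonded chain carbon. In a functional assay on MCF7 cells (Homo sapiens) for cytotoxicity, read by CellTiter-Glo, with a stated time of 5 days (on this read-out higher numbers stand for weaker inhibition and lower numbers for stronger inhibition), compound 1 gives 63 nM. Compound 3 `O=C(O)/C=C/c1ccc(/C(=C(\c2ccccc2)C(F)F)c2ccc3[nH]ncc3c2)cc1`, bearing difluoromethyl there, gives 14 nM in this assay. Compound 2 `O=C(O)/C=C/c1ccc(/C(=C(/CCO)c2ccccc2)c2ccc3[nH]ncc3c2)cc1`, bearing 2-hydroxyethyl, gives > 1000 nM in this assay, which is a limit of the assay and not a number (the limit of > 1000 nM in this assay, at which 1 of the 3 values shown sits); compound 2 therefore stands at the weak end of the values shown, and its steps are known only as lower bounds.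

Compound 4 `CC(C)/C(=C(/c1ccc(/C=C/C(=O)O)cc1)c1ccc2[nH]ncc2c1)c1ccccc1` is not yet measured. The change from compound 2 is isopropyl in place of 2-hydroxyethyl on a double-bonded chain carbon bound to an aromatic carbon and a double-bonded chain carbon. For the measured compounds named here, two measured steps bear on it: an at least 71-fold lower number from compound 2 to compound 3 (1.85 log units; beyond the scatter), and an at least 15-fold higher number from compound 1 to compound 2 (1.20 log units; beyond the scatter). Both show that replacing or capping the 2-hydroxyethyl chain brings a large gain, so a large drop in the number is expected for the step of an at least 25-fold lower number from compound 2 to compound 4 (1.39 log units; beyond the scatter). Compound 4 is estimated at 40 nM, with a range from 10 nM to 160 nM.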

Compound 4, half-maximal inhibitory concentration: 4 nM
Estimate against measurement, compound 4: 10-fold (1.00 log units) above, outside the stated range (below it).
By their numbers in this assay, from the lowest: compound 4; then compound 3; then compound 1. At a limit, above all of these: compound 2.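

In this assay isopropyl brings a 16-fold lower number from compound 1 to compound 4 (1.20 log units; beyond the scatter) and a 3.5-fold lower number from compound 3 to compound 4 (0.54 log units; beyond the scatter), so the lowest number at this position now belongs to a group of carbon only, not to difluoromethyl. Against 2-hydroxyethyl, which matches it in heavy atoms but carries an oxygen with a hydrogen-bond donor and acceptor, the change brings an at least 250-fold lower number from compound 2 to compound 4 (2.39 log units; beyond the scatter), so the heavy-atom count alone does not set the number in this pair. Compound 2 is a limit of the assay and not a number, so that step is a lower bound only: the limit of > 1000 nM in this assay, at which 1 of the 4 values shown sits.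

The compounds shown do not separate the loss of the oxygen from the branching of isopropyl. Going by these compounds, whether a straight propyl chain, a cyclopropyl ring or an amine at this place would keep the number of compound 4 stays open.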